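The source may report more compounds than this note shows. Statements on the series, on what has been measured and on what is new or still open speak of the compounds shown alone.

Working notes on the series. In a functional assay on CNE cells (Homo sapiens) for cytotoxicity, read by MTT assay, with a stated time of 72 h (a lower number here means a stronger inhibitor, a higher number a weaker inhibitor), compound 1, `CCOc1ccc(COc2c(OC)cc(/C=C/C(=O)OCC(=O)Nc3ccccc3)cc2OC)cc1`, gives only a limit, > 200000 nM. Compound 2, `COc1cc(/C=C/C(=O)OCC(=O)Nc2ccc(Cl)cc2)cc(OC)c1OCc1ccc(Cl)c(Cl)c1`, in this assay likewise reaches only a limit, > 200000 nM. Compound 2 therefore stands at the limit of the assay itself, and the limit of > 200000 nM in this assay, at which 2 of the 2 values shown sit, records that both values shown sit there, so no ranking among the measured compounds is possible. The step to compound 3, `CCOc1ccc(COc2c(OC)cc(/C=C/C(=O)OCC(=O)Nc3ccc(Cl)cc3)cc2OC)cc1`, is 4-ethoxyphenyl in place of 3,4-dichlorophenyl on a saturated chain carbon bound to an oxygen on an aromatic ring. Within the data shown here, no step between two measured compounds is available, so the size of this change cannot be read from the numbers. Compound 1 already carries the (4-ethoxybenzyl)oxy group and also sits at the limit. The step from compound 2 to compound 3 is expected to be none beyond the scatter, a step that the limit leaves unreadable from compound 2 to compound 3. For compound 3 the estimate in this assay is 250000 nM, in the range 100000 nM to 1000000 nM, most likely again reported only as a limit.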

Compound 3, half-maximal inhibitory concentration: > 200000 nM
Compound 3: a limit, no number (the forecaster's own chance of this, stated with the estimate: 85%); the middle value lies beyond the limit too.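

Among these compounds, compound 3 also stays at a limit, so no step from compound 1 or compound 2 to compound 3 can be read: the limit of > 200000 nM in this assay, at which 3 of the 3 values shown sit. The compounds shown leave open whether 4-ethoxyphenyl in place of 3,4-dichlorophenyl, or chloro in place of hydrogen, changes anything in this assay.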